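A few compounds are considered here, and "the series" means these few. Any claim that something is new, unique, unknown or untested is made for them only; others in the source may bear on it.

Measured so far in an ADME assay on HepG2 cells (Homo sapiens) for cytotoxicity, read by MTT assay, with a stated time of 24 h; on this read-out lower numbers stand for higher toxicity in this test and higher numbers for lower toxicity in this test:
- compound 1 `OCCCc1cn(-c2ccnc3cc(Cl)ccc23)nn1`: 151000 nM
- compound 2 `O=C(OCCCc1cn(-c2ccnc3cc(Cl)ccc23)nn1)c1ccccc1`: 1200000 nM
- compound 3 `COc1ccc(C(=O)OCCCc2cn(-c3ccnc4cc(Cl)ccc34)nn2)cc1`: 347000 nM

Compound 3 stands second highest of the three numbers in this assay. Its nearest neighbour is compound 1, with a 2.3-fold higher number from compound 1 to compound 3 (0.36 log units; beyond the scatter) separating them; its furthest is compound 2, the step being a 3.5-fold lower number from compound 2 to compound 3 (0.54 log units; beyond the scatter). Both steps lie beyond the scatter, so compound 3 sits between the bare alcohol and the unsubstituted ester.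

Compound 4 `CCc1ccc(C(=O)OCCCc2cn(-c3ccnc4cc(Cl)ccc34)nn2)cc1` is the next member. It differs from compound 3 by ethyl in place of methoxy on an aromatic carbon. Among the measured compounds shown here, no measured pair shows ethyl in place of methoxy directly. For the measured compounds named here, the step that bears on it is the one from compound 2 to compound 3, methoxy in place of hydrogen on an aromatic carbon, which gave a 3.5-fold lower number from compound 2 to compound 3 (0.54 log units; beyond the scatter), a modest move. Compound 4 removes that methoxy and puts ethyl in its place, so the expectation is that compound 4 moves back toward compound 2 without reaching it; the step from compound 3 to compound 4 is estimated as a 1.6-fold higher number from compound 3 to compound 4 (0.20 log units; within the scatter) in this assay. Compound 4 is thus expected to give about 550000 nM, with a range from 220000 nM to 1300000 nM.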

Compound 4, half-maximal cytotoxic concentration: > 2550000 nM
Compound 4: a limit, no number; the forecaster's own chance of this, stated with the estimate: 10%; middle value at least 4.6-fold (0.66 log units) away from the limit.
By their numbers in this assay, from the lowest: compound 1; then compound 3; then compound 2. At a limit, above all of these: compound 4.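

Compound 4 gives a limit and not a number in this assay: the limit of > 2550000 nM in this assay, at which 1 of the 4 values shown sits. Among the compounds shown here, on the aromatic carbon para to a large group, the earlier compounds showed only methoxy in place of hydrogen, which lowered the number, whereas ethyl in place of hydrogen raises it (an at least 2.1-fold higher number from compound 2 to compound 4 (0.32 log units; beyond the scatter)), so the direction of change at this place depends on the group that enters and not merely on the carbon being substituted. Ethyl in place of methoxy, with the same count of heavy atoms, also moves the number up (an at least 7.3-fold higher number from compound 3 to compound 4 (0.86 log units; beyond the scatter)), and (4-ethylphenyl)carbonyl in place of hydrogen on the oxygen of compound 1 gives the largest step in the series (an at least 16-fold higher number from compound 1 to compound 4 (1.22 log units; beyond the scatter)), pointing to lower toxicity in this test for that ester.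

With hydrogen, methoxy and ethyl as the only groups shown at this carbon, the reading rests on three compounds, and the steps to compound 4 give only a minimum size. Going by these compounds, whether a longer chain such as propyl follows ethyl, and whether an amine or a carboxylic acid at this carbon follows methoxy, remains open.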